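The compounds below may be only part of what the source reports. "The series", "measured", "known", "first", "only" and "open" are said of these compounds alone.

Measured in a toxicity assay on MDCK cells (Canis lupus familiaris) for cytotoxicity, read by CCK-8 assay, with a stated time of 48 h; on this read-out lower numbers stand for higher toxicity in this test and higher numbers for lower toxicity in this test:
compound 1 `CCOc1ccc(C(=O)NNc2c(Br)cccc2Br)cc1`: > 100000 nM (a limit)
compound 2 `CCN(CC)c1ccc(C(=O)NNc2c(Br)cccc2Br)cc1`: 34000 nM

The value of compound 1 is a limit of the assay and not a number. Compound 2 holds the only number shown so far. Compound 3 `O=C(NNc1c(Br)cccc1Br)c1ccc(B(O)O)cc1` differs from compound 2 by one change: a group of 3 heavy atoms (1 boron, 2 oxygen; no ring) in place of a group of 5 heavy atoms (4 carbon, 1 nitrogen; no ring), on an aromatic carbon, on an aromatic carbon. Among the compounds with values here, the one measured step that bears on it, an at least 2.9-fold lower number from compound 1 to compound 2 (0.46 log units; beyond the scatter), put diethylamino in place of ethoxy on an aromatic carbon. Its size rests on the limit of > 100000 nM in this assay, at which 1 of the 2 values shown sits, as its open end. With diethylamino leaving, a step of like size toward a higher number is expected in this assay, although the entering group has not been tested in this series. The expected step is a 2.1-fold higher number from compound 2 to compound 3 (0.31 log units; beyond the scatter) on this estimate. For compound 3 the estimated value is 70000 nM, with an expected range from 25000 nM to 150000 nM in this assay.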

Compound 3, half-maximal cytotoxic concentration: > 100000 nM
Compound 3 ended at the assay's limit (the forecaster's own chance of this, stated with the estimate: 35%); middle value at least 1.4-fold (0.15 log units) from the limit.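

In this assay, within the data shown here, a second group in place of diethylamino, the group of 3 heavy atoms (1 boron, 2 oxygen), gives an at least 2.9-fold higher number from compound 2 to compound 3 (0.46 log units; beyond the scatter), so diethylamino is now the only one of the three groups at this position with a number. The value of compound 3 is a limit and not a number: the limit of > 100000 nM in this assay, at which 2 of the 3 values shown sit. Between compound 1 and compound 3, both limits, no step can be read.

Open, going by these compounds, is how a smaller amine, such as dimethylamino, or a carboxylic acid would read at this position. Also open, on these data alone, is how far compound 1 and compound 3 lie from each other beyond the limit.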